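Swapping the ring on the amide arm of compound 2

The compounds below may be only part of what the source reports. "The series", "measured", "known", "first", "only" and "open" are said of these compounds alone.

Measured compounds:
compound 1, `CCC(=O)N1N=C(c2cc3ccccc3oc2=O)CC1c1ccccc1`: 4370 nM
compound 2, `O=C(CN1CCC(O)CC1)N1N=C(c2cc3ccccc3oc2=O)CC1c1ccccc1`: "not active" (no number reported)

Compound 1 carries a propanoyl group on the shared core and in a functional assay on PC-3 cells (Homo sapiens) for cytotoxicity, read by MTT assay, with a stated time of 48 h (a lower number here means a stronger inhibitor, a higher number a weaker inhibitor), compound 1 gives 4370 nM. Compound 2 carries an extended amide arm instead, and in this assay compound 2 is reported as "not active" (no number reported), with no number given. Among the measured compounds shown here, compound 2 therefore has no fixed place on the scale; the only reading is that it falls short of compound 1.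

Compound 3, `CN1CCN(CC(=O)N2N=C(c3cc4ccccc4oc3=O)CC2c2ccccc2)CC1`, differs from compound 2 by a single exchange: 4-methylpiperazin-1-yl in place of 4-hydroxypiperidin-1-yl on a saturated chain carbon bound to a carbonyl carbon. For the measured compounds named here, no measured pair shows this exchange, so the size of the step in this assay is unknown. With compound 2 giving no number and compound 1 giving 4370 nM, the expectation is that compound 3 remains weak, with a fair chance that this assay again reports no number. Compound 3 is estimated at 20000 nM, within a range from 4000 nM to 100000 nM.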

Compound 3, half-maximal inhibitory concentration: 25800 nM
Compound 3: middle estimate off by 1.3-fold (0.11 log units), on the low side, and the stated range covers the measured number.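

In this assay, among the compounds shown here, compound 3 gives 25800 nM and so puts the first number on an extended amide arm, showing that a ring on a saturated chain carbon bound to a carbonyl carbon can still give a reading. Putting 4-methylpiperazin-1-yl in place of methyl at that carbon brings a 5.9-fold higher number from compound 1 to compound 3 (0.77 log units; beyond the scatter) and thus a modest weakening beyond the scatter, which gives a size that the absent number of compound 2 could not. The exchange of 4-hydroxypiperidin-1-yl for 4-methylpiperazin-1-yl separates a compound reported as not active from one with a number, but that step cannot be read as a size, and no measurement at hand explains the difference.

Open, on these data alone, is whether morpholin-4-yl or an open dimethylamino group at the same carbon would read closer to compound 1 or compound 3. The compounds shown also do not say how a longer chain between the carbonyl and the 4-methylpiperazin-1-yl ring would read.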